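Amine Substituent Swap on a Fused Bicyclic Amide

The source may hold more compounds than are shown below. What is called first, only, known or untested is meant among the compounds shown, and "the series" means these compounds.

Compound 1 `CC(C)c1nc(C(=O)NCC2(C)CCN(CC3CCOCC3)CC2)c2ccccn12`: 53 nM
Compound 2 `CC(C)c1nc(C(=O)NC[C@@H]2[C@H]3CN(CC4CCC4)C[C@@H]23)c2ccccn12`: 13.2 nM
Compound 3 `CC(C)c1nc(C(=O)NC[C@@H]2[C@H]3CN(C4CCOCC4)C[C@@H]23)c2ccccn12`: 20.7 nM

In a functional assay on CHO cells for agonist activity at 5-hydroxytryptamine receptor 4 (Homo sapiens), read by a luciferase reporter and cAMP accumulation, with a stated time of 4 h (a lower number here means that less compound is needed, a higher number that more compound is needed for the effect), compound 3 gives 20.7 nM, the second highest of the three numbers. Its nearest neighbour, compound 2, gives 13.2 nM, within the scatter of compound 3, while compound 1 gives 53 nM, the furthest away and beyond the scatter.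

Compound 4 `CC(C)c1nc(C(=O)NC[C@@H]2[C@H]3CN(CC(C)(C)CO)C[C@@H]23)c2ccccn12` differs from compound 3 in one place: 2-(hydroxymethyl)-2-methylpropyl in place of oxan-4-yl on an amine nitrogen in a ring. For the measured compounds named here, the only measured step at this position is a 1.6-fold higher number from compound 2 to compound 3 (0.20 log units; within the scatter), which stayed within the scatter. On that basis the step of a 1.2-fold higher number from compound 3 to compound 4 (0.08 log units; within the scatter) is expected to be small, with no direction beyond the scatter. Compound 4 is therefore estimated at 25 nM, with a range from 8 nM to 80 nM.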

Compound 4, half-maximal effective concentration: 5.7 nM
Compound 4: the middle estimate sits 4.4-fold (0.64 log units) above what was measured; measured number below the stated range.
By their numbers in this assay, from the lowest: compound 4; then compounds 2 and 3 (each within the scatter of the next); then compound 1.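

Here a change on this amine nitrogen moves the number beyond the scatter in this assay with a 3.6-fold lower number from compound 3 to compound 4 (0.56 log units; beyond the scatter) and a 2.3-fold lower number from compound 2 to compound 4 (0.36 log units; beyond the scatter) as the two new steps, which the earlier swap did not do. The entering 2-(hydroxymethyl)-2-methylpropyl has no ring and carries a hydrogen-bond donor, unlike both oxan-4-yl and cyclobutylmethyl. No evidence at hand accounts for these steps.

Whether the hydroxyl or the open branched chain goes with the lower number stays open, as the compounds shown change both together. A 2,2-dimethylpropyl group on this nitrogen would separate the two.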